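The source may report more compounds than this note shows. Statements on the series, on what has been measured and on what is new or still open speak of the compounds shown alone.

Compound 1 `Cc1nn(-c2nc(-c3ccc(Cl)c(Cl)c3)c(SC(C)C)s2)c(C(=O)O)c1-c1cnccn1` gives 14000 nM in a functional assay on BJAB cells (Homo sapiens) for antiproliferative activity, with a stated time of 4 days; on this read-out lower numbers stand for an effect already at smaller amounts and higher numbers for an effect only at larger amounts of compound.
Compound 2 `Cc1cc(-c2c(C)nn(-c3nc(-c4ccc(Cl)c(Cl)c4)c(SC(C)C)s3)c2C(=O)O)cc(C)n1` gives 580 nM in this assay.
Compound 3 `Cc1nn(-c2nc(-c3ccc(Cl)c(Cl)c3)c(SC(C)C)s2)c(C(=O)O)c1-c1cccc(F)c1` gives 900 nM in this assay.

Among these three numbers compound 3 stands second highest. Its nearest neighbour is compound 2, and the step of a 1.6-fold higher number from compound 2 to compound 3 (0.19 log units; within the scatter) is within the scatter, so no order can be read between the two. Its furthest neighbour is compound 1, and the step of a 16-fold lower number from compound 1 to compound 3 (1.19 log units; beyond the scatter) is large and well beyond the scatter.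

Compound 4 `Cc1nn(-c2nc(-c3ccc(Cl)c(Cl)c3)c(SC(C)C)s2)c(C(=O)O)c1-c1ccc(Cl)cc1` differs from compound 3 in one place: 4-chlorophenyl in place of 3-fluorophenyl on an aromatic carbon. Of the measured steps, the two large ones, a 24-fold lower number from compound 1 to compound 2 (1.38 log units; beyond the scatter) and a 16-fold lower number from compound 1 to compound 3 (1.19 log units; beyond the scatter), both replace the pyrazin-2-yl group with a different six-membered aromatic ring, so they show that the choice of ring at this position matters greatly, but neither exchanges one halogen-bearing phenyl for another. Going by the values given here, the only step between two rings that both gave low numbers, a 1.6-fold higher number from compound 2 to compound 3 (0.19 log units; within the scatter), stays within the scatter. On that basis the change in compound 4 is expected to produce only a small step, a 1.1-fold lower number from compound 3 to compound 4 (0.05 log units; within the scatter), within the usual scatter rather than beyond it.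

Compound 4 is therefore estimated at 800 nM in this assay, with a range from 250 nM to 2500 nM.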

Compound 4, half-maximal effective concentration: 2500 nM
For compound 4 the middle estimate is 3.1-fold (0.49 log units) below the measured one; the measured number falls inside the stated range.
By their numbers in this assay, from the lowest: compounds 2 and 3 (each within the scatter of the next); then compound 4; then compound 1.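

In this assay, going by these compounds alone, exchanging one halogen-bearing phenyl for another is not a neutral swap at this position: a 2.8-fold higher number from compound 3 to compound 4 (0.44 log units; beyond the scatter) is a modest step beyond the scatter, whereas the one earlier step between two rings with low numbers stayed within it. Compound 4 also occupies a middle level, with a 4.3-fold higher number from compound 2 to compound 4 (0.63 log units; beyond the scatter) on one side and a 5.6-fold lower number from compound 1 to compound 4 (0.75 log units; beyond the scatter) on the other, so the position does more than set pyrazin-2-yl apart from the other rings, and a small change on the phenyl ring can shift the number measurably. Nothing available explains this shift in terms of a measured property of the compounds.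

The step from 3-fluorophenyl to 4-chlorophenyl changes both the halogen and where it sits on the phenyl ring, so the compounds shown cannot tell which of the two matters; 4-fluorophenyl or 3-chlorophenyl would separate them. It also remains open where a phenyl ring carrying an amine or a carboxylic acid at this position would fall among these levels.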